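The source may report more compounds than this note shows. Statements on the series, on what has been measured and on what is new or still open speak of the compounds shown alone.

Measured compounds:
- compound 1 `CC1(c2ccc(-c3ccc(/C(N)=N\O)cc3)cc2)CC(S(=O)(=O)c2ccc(F)cc2)=C(c2ccc(/C(N)=N\O)cc2)O1`: 3940 nM in an ADME assay on J774.A1 cells (Mus musculus) for cytotoxicity, read by MTT assay, with a stated time of 72 h; a higher number here means that more compound is tolerated, a lower number that less compound is tolerated
- compound 2 `CC1(c2ccc(-c3ccco3)cc2)CC(S(=O)(=O)c2ccc(F)cc2)=C(c2ccc(/C(N)=N\O)cc2)O1`: 4560 nM in this assay
- compound 3 `CC1(c2ccc(-c3cccc([N+](=O)[O-])c3)cc2)CC(S(=O)(=O)c2ccc(F)cc2)=C(c2ccc(/C(N)=N\O)cc2)O1`: 11100 nM in this assay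

Compound 3 gives the highest of the three numbers; the step is a 2.4-fold higher number from compound 2 to compound 3 (0.39 log units; beyond the scatter) and a 2.8-fold higher number from compound 1 to compound 3 (0.45 log units; beyond the scatter), both beyond the scatter, while compound 1 and compound 2 sit within the scatter of each other (a 1.2-fold higher number from compound 1 to compound 2 (0.06 log units; within the scatter)).

Compound 4 `COc1cc(-c2ccc(C3(C)CC(S(=O)(=O)c4ccc(F)cc4)=C(c4ccc(/C(N)=N\O)cc4)O3)cc2)cc(OC)c1OC` carries 3,4,5-trimethoxyphenyl in place of 3-nitrophenyl on an aromatic carbon. Both steps that reach compound 3 exchange the same distal aryl group and were modest, so another exchange at this position is expected to move the number only modestly, if at all, and without a clear direction. The step from compound 3 is expected to be a 1.4-fold lower number from compound 3 to compound 4 (0.14 log units; within the scatter). Compound 4 is therefore estimated at 8000 nM, with a range from 3000 nM to 22000 nM.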

Compound 4, half-maximal cytotoxic concentration: 5220 nM
Beside the measured number, compound 4's estimate is 1.5-fold (0.19 log units) above it, within the range that was stated.
By their numbers in this assay, from the lowest: compounds 1, 2 and 4 (each within the scatter of the next); then compound 3.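

In this assay the change to 3,4,5-trimethoxyphenyl gives a 2.1-fold lower number from compound 3 to compound 4 (0.33 log units; beyond the scatter), so the number reached with 3-nitrophenyl does not carry over to this larger aryl group. Against the other two compounds, a 1.1-fold higher number from compound 2 to compound 4 (0.06 log units; within the scatter) and a 1.3-fold higher number from compound 1 to compound 4 (0.12 log units; within the scatter), both within the scatter, so heavy-atom count at this position does not order the numbers, and 3-nitrophenyl alone stands apart. No evidence bears on the origin of this difference.

Open, as far as these compounds go, is whether the number of compound 3 is tied to the nitro group itself. An amine or a carboxylic acid in its place would test this.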